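A few compounds are considered here, and "the series" means these few. Any claim that something is new, unique, unknown or untested is made for them only; others in the source may bear on it.

Measured so far:
- Compound 1 `O=C1C(Nc2ccc(Br)cc2)=CC(=O)c2c1nc1n2[C@H]2OC[C@@H](O)[C@H]2OC1`: 5220 nM
- Compound 2 `O=C1C(N2CCCCC2)=CC(=O)c2c1nc1n2[C@H]2OC[C@@H](O)[C@H]2OC1`: > 16000 nM

Both results come from a functional assay on HeLa cells (Homo sapiens) for inhibition, read by sulforhodamine B assay; a higher number here means a weaker inhibitor, a lower number a stronger inhibitor. Compound 2 has no exact number here, only a limit of the assay, > 16000 nM.

The next compound, compound 3 `O=C1C(N2CCC2)=CC(=O)c2c1nc1n2[C@H]2OC[C@@H](O)[C@H]2OC1`, keeps the core of compound 2 and alters one group: azetidin-1-yl in place of piperidin-1-yl on a double-bonded ring carbon. A four-membered ring thus stands where a six-membered ring stood, on the same double-bonded ring carbon.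

Going by the values given here, only one measured step touches this place: an at least 3.0-fold higher number from compound 1 to compound 2 (0.48 log units; beyond the scatter). It bears on the new change only loosely, as compound 3 does not restore the (4-bromophenyl)amino group of compound 1. Among the compounds with values here, no measured step compares ring sizes, so the data favour no direction. A step beyond the usual scatter is therefore not expected, and compound 3 may also be reported only as a limit.

The expected result is a number no higher from compound 2 to compound 3 (the limit leaves the size open).

For compound 3, the estimated value in this assay is 16000 nM, with an expected range from 6000 nM to 40000 nM.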

Compound 3, half-maximal inhibitory concentration: > 16000 nM
Compound 3: only a limit was reported; the forecaster's own chance of this, stated with the estimate: 50%; the middle value lies on the limit itself.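

In this assay compound 3 stands at > 16000 nM as a limit and not as an exact number. Putting azetidin-1-yl in place of (4-bromophenyl)amino gives an at least 3.0-fold higher number from compound 1 to compound 3 (0.48 log units; beyond the scatter) and so adds a second ring on this double-bonded ring carbon, alongside the piperidin-1-yl of compound 2, that falls on the weaker side of compound 1. The step between compound 2 and compound 3 cannot be read, so the four-membered and six-membered rings cannot be ranked, and the smaller ring shows no exact value that could be set against compound 1: the limit of > 16000 nM in this assay, at which 2 of the 3 values shown sit.

As far as these compounds go, it remains open whether either ring has any measurable effect below this limit, and whether a different ring, such as morpholin-4-yl, would behave like these two. From the compounds shown here alone, it is also open which part of the (4-bromophenyl)amino group matters in compound 1, a question that a plain phenylamino group without the bromine, or a benzylamino group with one more carbon in its link, could begin to answer.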